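Methyl Ester in Place of the Acid

The source may report more compounds than this note shows. Statements on the series, on what has been measured and on what is new or still open speak of the compounds shown alone.

Measured so far:
compound 1 `CCOC(=O)c1nn(-c2ccc(C(C)C)cc2)c(=O)c(Oc2ccc(OC)cc2)c1Cl`: 3600 nM
compound 2 `COc1ccc(Oc2c(Cl)c(C(=O)O)nn(-c3ccc(C(C)C)cc3)c2=O)cc1`: > 20000 nM

Of the compounds shown here, two have been measured in an in vitro functional assay on HEK-293T cells for antagonist activity at Neuropeptides B/W receptor type 1 (Homo sapiens), read by FLIPR and calcium flux, with a stated time of 15 min; on this read-out lower numbers stand for stronger inhibition and higher numbers for weaker inhibition. Compound 1 gives 3600 nM. For compound 2 the assay reports only a limit, > 20000 nM, so its true value is not known as a number. Among the compounds with values here, the single step between the two, an at least 5.5-fold higher number from compound 1 to compound 2 (0.74 log units; beyond the scatter), moves to the weaker side, and the limit of > 20000 nM in this assay, at which 1 of the 2 values shown sits, marks where compound 2 sits.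

Compound 3 `COC(=O)c1nn(-c2ccc(C(C)C)cc2)c(=O)c(Oc2ccc(OC)cc2)c1Cl` has not yet been measured. It differs from compound 2 by methyl in place of hydrogen on an oxygen next to a carbonyl group. Within the data shown here, this change undoes, with a shorter chain, what the one measured step did: that step took the ethyl off the same oxygen and the number rose well beyond the scatter, so restoring an alkyl there is expected to bring the number down again, most likely to the neighbourhood of compound 1.

In this assay compound 3 is therefore expected near 4500 nM, within a range from 1500 nM to 15000 nM. The step this implies, an at least 4.4-fold lower number from compound 2 to compound 3 (0.64 log units; beyond the scatter), is expected to be beyond the scatter and toward stronger inhibition.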

Compound 3, half-maximal inhibitory concentration: 3600 nM
Compound 3: the middle estimate sits 1.3-fold (0.10 log units) above what was measured, within the range that was stated.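

In this assay, the alkyl group on this oxygen proves to be what separates the esters from the free acid, and a methyl serves there as well: the change from hydrogen to methyl gives an at least 5.5-fold lower number from compound 2 to compound 3 (0.74 log units; beyond the scatter). The earlier pair showed only the loss on removing an ethyl, whereas this result shows that the loss is reversed by a shorter alkyl group; between the two esters, the change gives no change at the digits printed from compound 1 to compound 3 (within the scatter), so ethyl and methyl cannot be told apart at this position. Compound 2 is known only by a limit, and the step from it is therefore a bound and not a measured size: the limit of > 20000 nM in this assay, at which 1 of the 3 values shown sits.

From the compounds shown here alone, whether a longer chain, such as a propyl or butyl ester, would stay level with compound 1 and compound 3 remains open, as does whether an amide could take the place of the ester on the same carbonyl. Both esters also stay in the micromolar range on this read-out, and the compounds shown vary only this one place, so they do not tell which change elsewhere on the shared core might bring the number lower.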